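A Methyl Added to the Chain of Compound 2

The source may report more compounds than this note shows. Statements on the series, on what has been measured and on what is new or still open speak of the compounds shown alone.

Compound 1 (`C[C@@H](N)C(=O)NCc1nnc(-c2ccccc2)o1`) and compound 2 (`COc1ccc(-c2nnc(CNC(=O)CN)o2)cc1`) have both been tested in a functional assay on MDA-MB-231 cells (Homo sapiens) for cytotoxicity, read by MTT assay, with a stated time of 24 h; on this read-out lower numbers stand for stronger inhibition and higher numbers for weaker inhibition. For the measured compounds named here, compound 1 gives 230 nM and compound 2 gives 276 nM, so compound 2 lies within the scatter of the only other measured value. Compound 3 (`COc1ccc(-c2nnc(CNC(=O)[C@@H](C)N)o2)cc1`) differs from compound 2 by methyl in place of hydrogen on a saturated chain carbon bound to an amine nitrogen and a carbonyl carbon, on a saturated chain carbon bound to an amine nitrogen and a carbonyl carbon. Going by the values given here, no measured step shows this change, and no shift beyond the scatter is expected in this assay. The expected step is a 1.1-fold lower number from compound 2 to compound 3 (0.04 log units; within the scatter). Compound 3 is estimated at 250 nM, with an expected range of 120 nM to 520 nM.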

Compound 3, half-maximal inhibitory concentration: 295 nM
Compound 3: the middle estimate sits 1.2-fold (0.07 log units) below what was measured, within the range that was stated.
By their numbers in this assay, from the lowest: compounds 1, 2 and 3 (each within the scatter of the next).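

In this assay, for the compounds shown here, the methyl on a saturated chain carbon bound to an amine nitrogen and a carbonyl carbon gives a 1.1-fold higher number from compound 2 to compound 3 (0.03 log units; within the scatter) and so stays within the scatter, which makes this the first measured reading of this change at this position. With that methyl in place, methoxy in place of hydrogen on an aromatic carbon gives a 1.3-fold higher number from compound 1 to compound 3 (0.11 log units; within the scatter) and also stays within the scatter. Nothing measured here bears on why either step is so small. Going by these compounds, whether an ethyl group or a longer chain at this carbon, or a chlorine or a carboxylic acid on the aromatic carbon, would move the number beyond the scatter remains open.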